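The compounds below may be only part of what the source reports. "The series", "measured", "known", "first", "only" and "open" are said of these compounds alone.

Measured in a physicochemical assay for solubility, at pH 4; on this read-out higher numbers stand for higher solubility and lower numbers for lower solubility:

- Compound 1 `CC[C@H]1OC(=O)[C@H](C)[C@@H](O[C@H]2C[C@@](C)(OC)[C@@H](O)[C@H](C)O2)[C@H](C)[C@@H](O[C@@H]2O[C@H](C)C[C@H](N(C)C)[C@H]2OCCCNC(=O)CNc2ccnc3ccccc23)[C@](C)(O)C[C@@H](C)CN(C)[C@H](C)[C@@H](O)[C@]1(C)O`: > 10000 ug/mL (a limit)
- Compound 2 `CC[C@H]1OC(=O)[C@H](C)[C@@H](O)[C@H](C)[C@@H](O[C@@H]2O[C@H](C)C[C@H](N(C)C)[C@H]2OCCCNC(=O)CNc2ccnc3cc(Cl)ccc23)[C@](C)(O)C[C@@H](C)CN(C)[C@H](C)[C@@H](O)[C@]1(C)O`: > 10000 ug/mL (a limit)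

Compound 2 has no exact number in this assay. Its reading of > 10000 ug/mL is a limit of the assay. Compound 1 is in the same position, and together they give (the limit of > 10000 ug/mL in this assay, at which 2 of the 2 values shown sit). The two compounds therefore cannot be ranked against each other.

The next compound is compound 3 `CC[C@H]1OC(=O)[C@H](C)[C@@H](O)[C@H](C)[C@@H](O[C@@H]2O[C@H](C)C[C@H](N(C)C)[C@H]2OCCCNC(=O)CNc2ccnc3ccccc23)[C@](C)(O)C[C@@H](C)CN(C)[C@H](C)[C@@H](O)[C@]1(C)O`, which has hydrogen in place of chloro on an aromatic carbon. Cut one bond further out, the same difference reads 7-chloroquinolin-4-yl to quinolin-4-yl. Among the compounds with values here, no measured pair shows the effect of this swap, so the expectation has little to rest on.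

The starting point is compound 2, whose > 10000 ug/mL is a limit. The expected step is a number no higher from compound 2 to compound 3 (the limit leaves the size open), no larger than the usual scatter of repeated measurements, with neither direction favoured. For compound 3 the estimate is 10000 ug/mL, with an expected range from 5000 ug/mL to 20000 ug/mL, and the assay will probably report only a limit again.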

Compound 3, solubility: > 10000 ug/mL
Compound 3: a limit, no number (the forecaster's own chance of this, stated with the estimate: 85%); the middle value lies on the limit itself.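

No step can be read from compound 2 to compound 3, or from compound 1 to compound 3, because all three compounds stop at the same limit: the limit of > 10000 ug/mL in this assay, at which 3 of the 3 values shown sit.

Going by these compounds, how far apart these compounds really lie in this assay, and whether hydrogen in place of chloro changes the read-out at all, stays open.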